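Methylation of the pyrrole nitrogen in the triazolothiadiazine series

A few compounds are considered here, and "the series" means these few. Any claim that something is new, unique, unknown or untested is made for them only; others in the source may bear on it.

Measured so far:
compound 1, `Cc1occc1-c1nnc2n1NC(c1ccco1)S2`, 25.9% in a functional assay on the whole organism (strain Wistar Albino) for inhibition, with Rattus norvegicus as the target, read by paw edema, with a stated time of 4 h, at a dose of 20 mg/kg; a higher number here means more inhibition at the dose given (going by the name of the read-out), a lower number less inhibition
compound 2, `Cc1occc1-c1nnc2n1NC(c1ccc[nH]1)S2`, 22.7%

For the measured compounds named here, compound 2 gives the lower of the two numbers in this assay, but the only step between measured compounds, a number 3.2 percentage points lower from compound 1 to compound 2 (within the scatter), lies within the scatter, so the two compounds cannot be ordered on these data.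

Compound 3, `Cc1occc1-c1nnc2n1NC(c1cccn1C)S2`, is not yet measured. It differs from compound 2 by methyl in place of hydrogen on an aromatic nitrogen.

Going by the values given here, no measured step addresses a change on the aromatic nitrogen of the 1H-pyrrol-2-yl group; the one step in hand, from compound 1 to compound 2, concerns a different change and was within the scatter. With nothing pointing either way, no step beyond the scatter is expected for compound 3, and its value is estimated to be 24%, in the range 12% to 36%, an expected step of a number 1.3 percentage points higher from compound 2 to compound 3 (within the scatter).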

Compound 3, a percentage reported as inhibition, in the whole organism at one dose (the size of the read-out at that dose, not a potency): 22.4%
The estimate for compound 3 lay 1.6 percentage points above the measured number; low and high end bracket the measured number.
By their numbers in this assay, from the lowest: compounds 3, 2 and 1 (each within the scatter of the next).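

In this assay, methyl in place of hydrogen on the aromatic nitrogen gives a number 0.3 percentage points lower from compound 2 to compound 3 (within the scatter), within the scatter, so the read-out at this dose does not separate 1-methyl-1H-pyrrol-2-yl from 1H-pyrrol-2-yl. Set against the furan-2-yl of compound 1, the methylated group gives a number 3.5 percentage points lower from compound 1 to compound 3 (within the scatter), also within the scatter, so neither group on the saturated ring carbon stands apart, and compounds 1, 2 and 3 cannot be ordered. No independent data on these compounds bear on this result.

As far as these compounds go, whether a longer chain, an amine or a carboxylic acid on that aromatic nitrogen would give a step beyond the scatter remains open. Also open, from the compounds shown here alone, is whether the three compounds would remain inseparable at another dose or read-out time.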